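The compounds below may be only part of what the source reports. "The series", "measured", "known", "first", "only" and "open" are said of these compounds alone.

Measured compounds:
- Compound 1, `CN(CCCCN(C)c1ncnc2c1ncn2[C@@H]1O[C@H](COP(=O)(O)OP(=O)(O)OP(=O)(O)O)[C@@H](O)[C@H]1O)C(=O)CCCNC(=O)CI`, in an assay on isolated protein for inhibition of hexokinase-3 (Rattus norvegicus), with a stated time of 6 h, tested at 10 mM (a higher number here means more inhibition at the concentration tested (going by the name of the read-out), a lower number less inhibition), gives 0%.
- Compound 2, `O=C(CI)NCCCCCCCNc1ncnc2c1ncn2[C@@H]1O[C@H](COP(=O)(O)OP(=O)(O)OP(=O)(O)O)[C@@H](O)[C@H]1O`, in this assay gives 20%.

Compound 1 stands at the lower of the two numbers; compound 2 sits above it by a margin beyond the usual scatter. The two differ in more than one place, so nothing more than the two values themselves can be read from the pair.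

Compound 3, `CN(CCCCN(C)c1ncnc2c1ncn2[C@@H]1O[C@H](COP(=O)(O)OP(=O)(O)OP(=O)(O)O)[C@@H](O)[C@H]1O)C(=O)CCCCCNC(=O)CI`, is not yet measured. It differs from compound 1 in one place: 2-(((iodomethyl)carbonyl)amino)ethyl in place of ((iodomethyl)carbonyl)amino on a saturated chain carbon, three bonds along the chain from a carbonyl carbon. Among the compounds with values here, no step between measured compounds covers a change of this kind, so no measured step is available to set the size.

Given that compound 1 gives 0%, the step from compound 1 to compound 3 is expected to be small, at most a modest rise, and may well fall within the scatter: a number 6 percentage points higher from compound 1 to compound 3 (within the scatter). Compound 3 is accordingly estimated at 6%, within 0% to 20%.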

Compound 3, a percentage reported as inhibition, at one concentration (the size of the read-out at that concentration, not a potency): 0%
Compound 3: the middle estimate sits 6 percentage points above what was measured; low and high end bracket the measured number.
By their numbers in this assay, from the lowest: compounds 1 and 3 (each within the scatter of the next); then compound 2.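

In this assay, within the data shown here, 2-(((iodomethyl)carbonyl)amino)ethyl in place of ((iodomethyl)carbonyl)amino on a saturated chain carbon, three bonds along the chain from a carbonyl carbon, gives no change at the digits printed from compound 1 to compound 3 (within the scatter), the first reading of any change at this position. Among these compounds, compound 1 already gives 0%, so this pair shows only that the added length brings no gain in inhibition at the concentration tested, and it cannot show a loss. No supporting measurement is available to explain this flat result.

Still open, as far as these compounds go, is whether a longer chain, such as 5-(((iodomethyl)carbonyl)amino)pentyl, would give a reading different from that of compound 3 in this assay. Also open, from the compounds shown here alone, is what replacing the iodomethyl carbonyl end with a bromomethyl or chloromethyl carbonyl group at this position would do.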